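Swapping Methoxy for Trifluoromethyl on a Benzyl Piperazine

The source may report more compounds than this note shows. Statements on the series, on what has been measured and on what is new or still open speak of the compounds shown alone.

Of the compounds shown here, three with a shared core have been tested in an assay on isolated protein for displacement of a labelled ligand from Apoptosis regulator Bcl-2 (Homo sapiens), read by fluorescence polarization; on this read-out higher numbers stand for weaker inhibition and lower numbers for stronger inhibition. Compound 1 `CN(C)CC[C@H](CSc1ccccc1)Nc1ccc(S(=O)(=O)NC(=O)c2ccc(N3CCC(=Cc4ccccc4C(F)(F)F)CC3)cc2)cc1[N+](=O)[O-]` gives 2 nM. Compound 2 `CC1OC2(CCN(c3ccc(C(=O)NS(=O)(=O)c4ccc(N[C@H](CCN(C)C)CSc5ccccc5)c([N+](=O)[O-])c4)cc3)CC2)N(Cc2ccccc2)C1=O` gives 9.6 nM. Compound 3 `COc1ccccc1CN1CCN(c2ccc(C(=O)NS(=O)(=O)c3ccc(N[C@H](CCN(C)C)CSc4ccccc4)c([N+](=O)[O-])c3)cc2)CC1` gives 3.2 nM. Among these three numbers compound 3 stands second highest: its nearest neighbour is compound 1, whose number is lower by an amount that sits within the usual scatter of repeated measurements, while compound 2 has a higher number and lies beyond that scatter. No two of the measured compounds differ in only one place, so no single structural change can be read off from the measured values alone.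

Compound 4 `CN(C)CC[C@H](CSc1ccccc1)Nc1ccc(S(=O)(=O)NC(=O)c2ccc(N3CCN(Cc4ccccc4C(F)(F)F)CC3)cc2)cc1[N+](=O)[O-]` has not yet been measured. It is compound 3 with one change: trifluoromethyl in place of methoxy on an aromatic carbon, at a position described as ortho to a large group. Compound 1 also carries a trifluoromethyl group on its outer ring and compound 1 gives 2 nM, but its remaining parts differ as well, so this is only a loose hint.

Compound 4 is expected to give 2.5 nM, with a range from 1 nM to 7 nM. The expected step is a 1.3-fold lower number from compound 3 to compound 4 (0.11 log units; within the scatter), which means no change beyond the scatter in this assay.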

Compound 4, inhibition constant: < 1 nM
Compound 4: no number, only a limit; the forecaster's own chance of this, stated with the estimate: 0%; at least 2.5-fold (0.39 log units) between middle value and limit.
By their numbers in this assay, from the lowest: compounds 1 and 3 (each within the scatter of the next); then compound 2. At a limit, below all of these: compound 4.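

In this assay compound 4 reads < 1 nM, which is a limit of the assay and not a number. Within the data shown here, this is the first comparison here between two compounds that differ in only one place: trifluoromethyl replaces methoxy on an aromatic carbon, ortho to a large group, and the result is an at least 3.2-fold lower number from compound 3 to compound 4 (0.50 log units; beyond the scatter), so what sits at this position on the outer ring matters in this assay. The step is only a minimum, and how far compound 4 lies past it cannot be read: the limit of < 1 nM in this assay, at which 1 of the 4 values shown sits.

On these data alone, whether the gain comes from trifluoromethyl itself or simply from losing methoxy stays open, and a bare hydrogen or a chlorine atom at this position would help separate the two readings. Also open, as far as these compounds go, is whether the same swap would move the number by a similar amount on the outer ring of compound 2, where the rest of the molecule is different.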